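Replacing the 4-methoxypiperidin-1-yl group in compound 1

The compounds below may be only part of what the source reports. "The series", "measured", "known", "first", "only" and "open" are said of these compounds alone.

In a functional assay on MGC-803 cells (Homo sapiens) for cytotoxicity, read by MTT assay, with a stated time of 48 h (a higher number here means a weaker inhibitor, a lower number a stronger inhibitor), compound 1 `COc1ccccc1C1CC(C)=NN1C(=O)CN1CCC(OC)CC1` gives 9550 nM, while compound 2 `CC(=O)Oc1ccccc1C1CC(C)=NN1C(=O)CCl` gives 3010 nM. Compound 1 therefore holds the higher of the two numbers and is the weaker inhibitor of this pair, with a gap beyond the usual scatter. For the measured compounds named here, with only two measured compounds, no trend can be drawn from these values.

Compound 3 `CC[N+](C)(CC)CC(=O)N1N=C(C)CC1c1ccccc1OC` keeps the core of compound 1 and changes one group: a group of 6 heavy atoms (5 carbon, 1 nitrogen; no ring) in place of a group of 8 heavy atoms (6 carbon, 1 nitrogen, 1 oxygen; one six-membered non-aromatic ring with 1 hetero atom), on a saturated chain carbon bound to a carbonyl carbon. The 4-methoxypiperidin-1-yl group leaves, and a group with no ring and a net charge of +1 enters, on a saturated chain carbon bound to a carbonyl carbon.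

Going by the values given here, no measured pair in this small set shows a single change of this kind, so the size of the step has no direct precedent. A step beyond the scatter is not expected in this assay, and neither direction is favoured. The expectation therefore starts from compound 1 at 9550 nM, and the expected change is a 1.0-fold higher number from compound 1 to compound 3 (0.02 log units; within the scatter). Compound 3 is estimated at 10000 nM, with an expected range of 3000 nM to 35000 nM.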

Compound 3, half-maximal inhibitory concentration: 3320 nM
For compound 3 the middle estimate is 3.0-fold (0.48 log units) above the measured one; the range from low to high includes it.
By their numbers in this assay, from the lowest: compounds 2 and 3 (each within the scatter of the next); then compound 1.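

The position on the saturated chain carbon bound to a carbonyl carbon responds to its substituent in this assay: replacing the 4-methoxypiperidin-1-yl group with the ringless group of net charge +1 gives a 2.9-fold lower number from compound 1 to compound 3 (0.46 log units; beyond the scatter), a modest step but the first single-place change seen in the series. The 4-methoxypiperidin-1-yl group is therefore not needed to hold this level of cytotoxicity, since a group with no ring, no hydrogen-bond acceptors and fewer heavy atoms gives the lower number on the same core. No measurement available here explains the step, and the ring, the oxygen, the size and the charge all change together in this one exchange.

The compounds shown leave open which of these differences carries the step. An uncharged diethylamino group on the same carbon would set the charge apart from the loss of the ring, and a plain piperidin-1-yl group would show what the methoxy group contributes with the ring kept.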